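A few compounds are considered here, and "the series" means these few. Any claim that something is new, unique, unknown or untested is made for them only; others in the source may bear on it.

Measured in a functional assay on A549 cells (Homo sapiens) for antiproliferative activity, read by MTT assay, with a stated time of 48 h; a lower number here means a stronger inhibitor, a higher number a weaker inhibitor:
- compound 1 `COc1ccc(N(C)c2ccnc(Cl)n2)cc1F`: 651 nM
- compound 2 `COc1ccc(N(C)c2ccnc(Cl)n2)cc1OCCBr`: 4640 nM
- compound 3 `COc1ccc(N(C)c2ccnc(Cl)n2)cc1OCCCBr`: 862 nM

Compound 3 lies within the scatter of compound 1, as a 1.3-fold higher number from compound 1 to compound 3 (0.12 log units; within the scatter) shows, and well under compound 2, as a 5.4-fold lower number from compound 2 to compound 3 (0.73 log units; beyond the scatter) shows. The next compound is compound 4 `COc1ccc(N(C)c2ccnc(Cl)n2)cc1OCC[Se]C#N`, and the change is a group of 3 heavy atoms (1 carbon, 1 nitrogen, 1 selenium; no ring) in place of a group of 2 heavy atoms (1 carbon, 1 bromine; no ring), on a saturated chain carbon, two bonds along the chain from an oxygen on an aromatic ring. A group of 3 heavy atoms replaces bromomethyl on a saturated chain carbon, two bonds along the chain from an oxygen on an aromatic ring.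

For the measured compounds named here, no measured step makes this exchange, so the data offer only an indirect guide. The closest evidence is the modest change at the chain end in a 5.4-fold lower number from compound 2 to compound 3 (0.73 log units; beyond the scatter), while a 1.3-fold higher number from compound 1 to compound 3 (0.12 log units; within the scatter) stays within the scatter. A step of modest size at most is therefore expected in this assay, with a slight lean towards a lower number and the direction uncertain. The expected change is a 1.7-fold lower number from compound 3 to compound 4 (0.24 log units; within the scatter). For compound 4 the estimated value is 500 nM, with an expected range of 100 nM to 3000 nM.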

Compound 4, half-maximal inhibitory concentration: 463 nM
Compound 4: the middle estimate sits 1.1-fold (0.03 log units) above what was measured, and the stated range covers the measured number.
By their numbers in this assay, from the lowest: compounds 4, 1 and 3 (each within the scatter of the next); then compound 2.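

In this assay, for the compounds shown here, the group of carbon, nitrogen and selenium, set on the chain of compound 2 in place of its bromine, gives a 10-fold lower number from compound 2 to compound 4 (1.00 log units; beyond the scatter) and so shows for the first time that, with the chain held fixed, the atoms at its end alone can move the number beyond the scatter. The same group brings no separation from the bromomethyl-ended chain or from the fluoro compound, as a 1.9-fold lower number from compound 3 to compound 4 (0.27 log units; within the scatter) and a 1.4-fold lower number from compound 1 to compound 4 (0.15 log units; within the scatter) show, so the high number of compound 2 stands alone among these four compounds. Nothing measured here accounts for these differences.

The compounds shown leave open whether the selenium group would hold this level on a longer chain. They also leave open how an amine at the chain end would compare.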